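The source may hold more compounds than are shown below. What is called first, only, known or untested is meant among the compounds shown, and "the series" means these compounds.

Measured compounds:
compound 1, `O=C1/C(=C/c2ccc(F)cc2)CCC/C1=C\c1ccccc1[N+](=O)[O-]`, 4.86
compound 2, `O=C1/C(=C/c2ccc(Cl)cc2)CCC/C1=C\c1ccccc1[N+](=O)[O-]`, 5.38
compound 3, `O=C1/C(=C/c2ccc(F)cc2)CCC/C1=C\c1ccc([N+](=O)[O-])cc1`, 5.09

The three compounds were measured in a physicochemical assay for lipophilicity; a lower number here means a more polar compound, a higher number a more lipophilic compound. Compound 1 and compound 2 share one core and differ in a single place: chloro in place of fluoro on an aromatic carbon. This change gave a number 0.52 log units higher from compound 1 to compound 2 (beyond the scatter). Compound 3 carries the fluoro group of compound 1 on a core of the same atoms joined differently; the difference between the two cores is not broken down here. In this assay compound 3 gives 5.09, and this number and that of compound 1 lie within the scatter of each other, so nothing can be said about an order between them.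

Compound 4, `O=C1/C(=C/c2ccc(Cl)cc2)CCC/C1=C\c1ccc([N+](=O)[O-])cc1`, has not yet been measured in this assay. Relative to compound 3 it shows (chloro in place of fluoro on an aromatic carbon). Among the compounds with values here, the place of the change reads the same in both pairs, so this is the same change as the one from compound 1 to compound 2. Within the data shown here, with only one measured step of this kind to go on, the expectation rests on that step: because compound 1 to compound 2 gave a number 0.52 log units higher from compound 1 to compound 2 (beyond the scatter), a step of similar size is expected, a number 0.51 log units higher from compound 3 to compound 4 (beyond the scatter). Compound 4 is therefore estimated at 5.6, with a likely range from 5.3 to 5.9.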

Compound 4, partition coefficient: 5.6
Compound 4: the middle estimate sits on the measured number at the digits printed; the range from low to high includes it.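

In this assay the change of fluoro to chloro on the second core gave a number 0.51 log units higher from compound 3 to compound 4 (beyond the scatter) and on the first core it gave a number 0.52 log units higher from compound 1 to compound 2 (beyond the scatter) so in these two pairs the step carried from one core to the other at nearly the same size, and each step lies beyond the scatter. This agreement rests on two pairs and two cores of the same atoms joined differently, so it does not show that the step would keep its size on any further core, or that a change other than this one would transfer in the same way. No measurement at hand bears on why the two steps match, and the agreement remains an observation without an explanation.

The compounds shown hold only fluoro and chloro in this place, so it stays open whether bromo, a methoxy group, an amine or a carboxylic acid there would give steps that also match between the two cores. As far as these compounds go, it also stays open whether the chloro step would hold if the nitro group of either core gave way to a nitrile or an amine.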